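Lengthening the fatty ester chain on a cytidine core

The source may hold more compounds than are shown below. What is called first, only, known or untested is meant among the compounds shown, and "the series" means these compounds.

Compound 1 `CCCCCCCCCCCCCCCC(=O)O[C@H]1[C@H](O)[C@H](n2ccc(N)nc2=O)O[C@@H]1CO`: in a functional assay on HeLa cells (Homo sapiens) for cytotoxicity, read by cell counting, with a stated time of 48 h (a lower number here means that less compound is needed, a higher number that more compound is needed for the effect), compound 1 gives 0.24 ug/mL.
Compound 2 `CCCCCCCCCCCCCCCCCCCC(=O)O[C@H]1[C@H](O)[C@H](n2ccc(N)nc2=O)O[C@@H]1CO`: in this assay compound 2 gives 0.1 ug/mL.

Going by the values given here, compound 2 has the lowest number of the two measured compounds; its only neighbour is compound 1, and the one measured step, a 2.4-fold lower number from compound 1 to compound 2 (0.38 log units; beyond the scatter), goes beyond the usual scatter. That step is a lengthening of the saturated ester chain, far from the carbonyl, and it went with a modest lowering of the number.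

Compound 3 `CCCCCCCCCCCCCCCCCCCCCC(=O)O[C@H]1[C@H](O)[C@H](n2ccc(N)nc2=O)O[C@@H]1CO` differs from compound 2 by ethyl in place of hydrogen on a saturated chain carbon, ten or more bonds along the chain from a carbonyl carbon. This is the same kind of change as the measured step, only shorter in what enters. Among the compounds with values here, the single step available gives some ground to expect a further lowering, but one step on two compounds cannot show whether the effect keeps growing or levels off, so the expected move is smaller and uncertain. The step expected from compound 2 to compound 3 is a 1.4-fold lower number from compound 2 to compound 3 (0.15 log units; within the scatter). Compound 3 is therefore estimated to give about 0.07 ug/mL, with a likely range from 0.03 ug/mL to 0.2 ug/mL.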

Compound 3, concentration for half-maximal effect: 1.1 ug/mL
Estimate against measurement, compound 3: 16-fold (1.20 log units) below, and the stated range ends below it.
By their numbers in this assay, from the lowest: compound 2; then compound 1; then compound 3.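

In this assay, adding to the far end of the saturated ester chain does not keep lowering the number: the earlier fall of a 2.4-fold lower number from compound 1 to compound 2 (0.38 log units; beyond the scatter) is followed by a sharp reversal, with an 11-fold higher number from compound 2 to compound 3 (1.04 log units; beyond the scatter) for the addition of just ethyl. Compound 3 also ends up worse than the shortest chain shown, with a 4.6-fold higher number from compound 1 to compound 3 (0.66 log units; beyond the scatter) across the whole change, so among these three compounds the number dips at compound 2 and then climbs past where it began, and the effect of chain length at this position is not a steady trend. Nothing measured alongside these numbers accounts for the reversal.

Three chain lengths cannot show whether the number turns gradually or abruptly, nor whether compound 2 marks the true lowest point of the series. From the compounds shown here alone, how a longer chain would read, or a chain of similar length carrying an amine or a carboxylic acid, remains open, as does whether the same turn would appear on any other kind of cell.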